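The source may report more compounds than this note shows. Statements on the series, on what has been measured and on what is new or still open speak of the compounds shown alone.

Measured compounds:
Compound 1, `CCOc1ccc(-n2nncc2CN2C(=O)C3(C(C#N)=C(N)Oc4c(N)cc5nc6ccccc6nc5c43)c3ccccc32)cc1`, in an ADME assay on HUVEC cells (Homo sapiens) for antiproliferative activity, read by MTT assay, with a stated time of 48 h (on this read-out lower numbers stand for stronger inhibition and higher numbers for weaker inhibition), gives > 50000 nM, which is a limit of the assay rather than a number.
Compound 2, `N#CC1=C(N)Oc2c(N)cc3nc4ccccc4nc3c2C12C(=O)N(Cc1cnnn1-c1cc(Cl)ccc1Cl)c1ccccc12`, in this assay gives > 50000 nM, likewise a limit of the assay rather than a number.

Compound 2 thus stands at the edge of what the assay can report: both values shown sit at the limit of > 50000 nM in this assay, at which 2 of the 2 values shown sit. Compound 3, `COc1ccc(OC)c(-n2nncc2CN2C(=O)C3(C(C#N)=C(N)Oc4c(N)cc5nc6ccccc6nc5c43)c3ccccc32)c1`, differs from compound 2 by 2,5-dimethoxyphenyl in place of 2,5-dichlorophenyl on an aromatic nitrogen. Within the data shown here, the only measured step on this aromatic nitrogen, a step that the two limits leave unreadable from compound 1 to compound 2, has no readable size, since both of its compounds reached only the limit. Among the measured compounds shown here, there is therefore no measured step that tells how large a change to expect in this assay, or in which direction, and no evidence that compound 3 would fall inside the measurable range. Compound 3 is accordingly estimated at 70000 nM, within 30000 nM to 200000 nM. This expected step is a step that the limit leaves unreadable from compound 2 to compound 3.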

Compound 3, half-maximal inhibitory concentration: > 50000 nM
Compound 3: only a limit was reported; the forecaster's own chance of this, stated with the estimate: 85%; the middle value is on the limit's open side.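

No step can be read among compound 1, compound 2 and compound 3, since each result in this assay is a limit of the assay and not a number: the limit of > 50000 nM in this assay, at which 3 of the 3 values shown sit.

The compounds shown leave open whether any group on this aromatic nitrogen would give a measurable value, and how large such a change would be.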